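The source may hold more compounds than are shown below. What is called first, only, known or untested is meant among the compounds shown, and "the series" means these compounds.

Notes on the series. Compound 1 `Nc1ncnc2c1c(Oc1cc(C(F)(F)F)ccn1)nn2[C@@H]1CCCC[C@H]1O` carries a 2-hydroxycyclohexyl on the shared core. In an ADME assay on microsomes from liver (Homo sapiens) for metabolic stability, read by LC-MS, using NADPH, with a stated time of 10 min, tested at 10 uM (a higher number here means that the compound lasts longer, a lower number that the compound disappears faster), compound 1 gives > 2.41 h, which is a limit of the assay and not a number. What is known of compound 1 is thus only (the limit of > 2.41 h in this assay, at which 1 of the 2 values shown sits). Compound 2 `CC(C)(C)n1nc(Oc2cc(Cl)ccn2)c2c(N)ncnc21` gives 1 h in this assay. Going by the values given here, compound 3 `Nc1ncnc2c1c(Oc1cc(C(F)(F)F)ccn1)nn2C1CCCCC1` differs from compound 1 by hydrogen in place of hydroxy on a saturated ring carbon; no measured step of this kind exists in the set. A modest shortening in this assay is expected, possibly within the scatter. Compound 3 is estimated at 1.5 h, between 0.5 h and 4 h, with the expected step of an at least 1.6-fold lower number from compound 1 to compound 3 (0.20 log units; that floor lies within the scatter).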

Compound 3, half-life: 0.55 h
The estimate for compound 3 lay 2.7-fold (0.44 log units) above the measured number; the measured number falls inside the stated range.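

Hydrogen in place of hydroxy on the saturated ring carbon gives an at least 4.3-fold lower number from compound 1 to compound 3 (0.64 log units; beyond the scatter) in this assay, the first step read at this position, and it lies beyond the scatter. The hydroxy position on the 2-hydroxycyclohexyl therefore counts for half-life in this pair. The size of the step is only a floor, and the reading for compound 1 is a limit of the assay: the limit of > 2.41 h in this assay, at which 1 of the 3 values shown sits.

Going by these compounds, the full size of the step stays open. So does whether hydroxy is specifically required, or whether a methoxy, an amine or a fluorine on the same ring carbon would give the same half-life.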